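Halogen swap on a bis-benzylidene piperidinone cytotoxicity series

The source may report more compounds than this note shows. Statements on the series, on what has been measured and on what is new or still open speak of the compounds shown alone.

Compound 1, `COc1cc(/C=C2\CN(C)C/C(=C\c3ccc(Cl)cc3)C2=O)cc(OC)c1OC`: > 20000 nM, a limit of the assay.
Compound 2, `COc1cc(/C=C2\CN(C)C/C(=C\c3ccc(Br)cc3)C2=O)cc(OC)c1OC`: 12400 nM.
Compound 3, `CN1C/C(=C\c2ccc(Cl)cc2)C(=O)/C(=C/c2cccc([N+](=O)[O-])c2)C1`: > 20000 nM, a limit of the assay.

The three measured compounds were tested in a functional assay on K562 cells (Homo sapiens) for cytotoxicity, read by MTT assay, with a stated time of 24 h; on this read-out higher numbers stand for weaker inhibition and lower numbers for stronger inhibition. Compound 1 reaches only the limit in this assay. Compound 2 gives a number, and the step of an at least 1.6-fold lower number from compound 1 to compound 2 (0.20 log units; that floor lies within the scatter) can only be stated as a floor because of the limit of > 20000 nM in this assay, at which 2 of the 3 values shown sit. The change behind that step is bromo in place of chloro on an aromatic carbon.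

Compound 3 also reaches only the limit in this assay. Its core differs from that of compound 1, and the difference between the two cores is not broken down here. Compound 4, `CN1C/C(=C\c2ccc(Br)cc2)C(=O)/C(=C/c2cccc([N+](=O)[O-])c2)C1`, has not yet been measured in this assay. It differs from compound 3 by bromo in place of chloro on an aromatic carbon, the same change as from compound 1 to compound 2, since both place lines read alike.

Given that compound 3 sits at the limit and that the only comparable step, an at least 1.6-fold lower number from compound 1 to compound 2 (0.20 log units; that floor lies within the scatter), was small, the expectation is a step of about an at least 1.1-fold lower number from compound 3 to compound 4 (0.04 log units; that floor lies within the scatter) for compound 4. Compound 4 is therefore estimated at 18000 nM, with a likely range from 9000 nM to 40000 nM, and a fair chance that this assay again reports only a limit.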

Compound 4, half-maximal inhibitory concentration: > 20000 nM
Compound 4: no number, only a limit; the forecaster's own chance of this, stated with the estimate: 55%; middle value at least 1.1-fold (0.04 log units) away from the limit.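

In this assay, compound 3 and compound 4 both reach only the limit, so no step between them can be read: the limit of > 20000 nM in this assay, at which 3 of the 4 values shown sit.

The compounds shown leave open whether bromo in place of chloro changes the number at all on the core of compound 3, and how compound 3 and compound 4 would compare if either gave a number rather than a limit.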